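Methoxy added to the phenylsulfonyl group of compound 2

The compounds below may be only part of what the source reports. "The series", "measured", "known", "first", "only" and "open" are said of these compounds alone.

In a functional assay on MCF7 cells (Homo sapiens) for antiproliferative activity, read by MTT assay, with a stated time of 24 h (on this read-out higher numbers stand for weaker inhibition and lower numbers for stronger inhibition), compound 1 (`COc1ccc(S(=O)(=O)n2c(-c3cn(-c4ccccc4)nc3-c3ccc(F)cc3)nc3ccccc32)cc1`) gives 530 nM and compound 2 (`O=S(=O)(c1ccccc1)n1c(-c2cn(-c3ccccc3)nc2-c2ccc(C(F)(F)F)cc2)nc2ccccc21`) gives 630 nM which places compound 2 within the scatter of compound 1. Compound 3 (`COc1ccc(S(=O)(=O)n2c(-c3cn(-c4ccccc4)nc3-c3ccc(C(F)(F)F)cc3)nc3ccccc32)cc1`) differs from compound 2 by methoxy in place of hydrogen on an aromatic carbon with methoxy in place of hydrogen on an aromatic carbon, turning phenylsulfonyl into (4-methoxyphenyl)sulfonyl. Compound 1 at 530 nM already carries that group, so no step beyond the scatter is expected in this assay for this change. The estimated step reads a 1.1-fold lower number from compound 2 to compound 3 (0.06 log units; within the scatter) on these grounds. For compound 3 the expected value is 550 nM (estimated range 220 nM to 1300 nM).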

Compound 3, half-maximal inhibitory concentration: 420 nM
Beside the measured number, compound 3's estimate is 1.3-fold (0.12 log units) above it, within the range that was stated.
By their numbers in this assay, from the lowest: compounds 3, 1 and 2 (each within the scatter of the next).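

In this assay methoxy in place of hydrogen on the phenylsulfonyl group reads a 1.5-fold lower number from compound 2 to compound 3 (0.18 log units; within the scatter) and so shows that this change, on a ring carbon para to a large group, gives no step beyond the scatter in the trifluoromethyl compounds. With (4-methoxyphenyl)sulfonyl held constant, trifluoromethyl in place of fluoro reads a 1.3-fold lower number from compound 1 to compound 3 (0.10 log units; within the scatter) and also stays within the scatter. No measurement on hand accounts for either step.

From the compounds shown here alone, whether an amine, a carboxylic acid or a longer chain such as butoxy at this ring carbon would move the number beyond the scatter remains open. So does the effect of any change on the other parts of the shared core.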